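A 2-chlorophenyl swap at the weak end of the series

This account rests on a few compounds, and the source may have more. Where it says the series, first, only, none or still open, it means among the compounds named here.

In a functional assay on HeLa cells (Homo sapiens) for cytotoxicity, read by MTT assay, with a stated time of 48 h (on this read-out lower numbers stand for stronger inhibition and higher numbers for weaker inhibition), compound 1 `Cc1nc2c3ccccc3ccc2c2nc3c(ccc4ccccc43)c(-c3cccc([N+](=O)[O-])c3)c12` gives 50700 nM and compound 2 `COc1ccc(-c2c3ccc4ccccc4c3nc3c2c(C)nc2c4ccccc4ccc32)cc1` gives 45900 nM, so these two share the weak end of the three numbers. Compound 3 `Cc1nc2c3ccccc3ccc2c2nc3c(ccc4ccccc43)c(-c3cc([N+](=O)[O-])ccc3N)c12` stands apart at 5770 nM. Compound 4 `Cc1nc2c3ccccc3ccc2c2nc3c(ccc4ccccc43)c(-c3ccccc3Cl)c12` has 2-chlorophenyl in place of 3-nitrophenyl on an aromatic carbon, opposite the ring nitrogen: 2-chlorophenyl in place of 3-nitrophenyl on an aromatic carbon. Among the measured compounds shown here, the closest precedent is another aryl exchange, a 1.1-fold lower number from compound 1 to compound 2 (0.04 log units; within the scatter). The larger step, an 8.8-fold lower number from compound 1 to compound 3 (0.94 log units; beyond the scatter), came with an added amino group, which compound 4 lacks. Only a small gain is therefore expected, with a wide margin. The expected step is a 1.5-fold lower number from compound 1 to compound 4 (0.19 log units; within the scatter). For compound 4 the estimated value is 33000 nM, within an expected range of 11000 nM to 75000 nM.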

Compound 4, half-maximal inhibitory concentration: > 80000 nM
Compound 4: no number, only a limit (the forecaster's own chance of this, stated with the estimate: 10%); at least 2.4-fold (0.38 log units) between middle value and limit.
By their numbers in this assay, from the lowest: compound 3; then compounds 2 and 1 (each within the scatter of the next). At a limit, above all of these: compound 4.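

Compound 4 gives no number in this assay, only a limit: the limit of > 80000 nM in this assay, at which 1 of the 4 values shown sits. Two of the steps, an at least 1.5-fold higher number from compound 1 to compound 4 (0.19 log units; that floor lies within the scatter) and an at least 1.7-fold higher number from compound 2 to compound 4 (0.24 log units; that floor lies within the scatter), have floors that do not separate these compounds. The third, an at least 13-fold higher number from compound 3 to compound 4 (1.14 log units; beyond the scatter), shows that an aryl group at this position, opposite the ring nitrogen, can leave the number far from the best of the series when it carries no amino group. The compounds shown leave open whether amino alone, as a plain 2-aminophenyl, would lower the number, and how a carboxylic acid on this ring would read.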